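Swapping the aryl amide on a shared diamine core

The source may hold more compounds than are shown below. What is called first, only, known or untested is meant among the compounds shown, and "the series" means these compounds.

Going by the values given here, compound 2 `Cc1cccc(C(=O)N[C@H]2CCC[C@H](NC(=O)c3cccc(Cl)c3)C2)n1` gives 582 nM in an assay on HEK293 cells for displacement of a labelled ligand from metabotropic glutamate receptor 5 (Homo sapiens), read by scintillation counting, with a stated time of 60 min (on this read-out lower numbers stand for stronger inhibition and higher numbers for weaker inhibition), the lowest of the two numbers measured so far, though compound 1 `COc1ccc(C(=O)N[C@H]2CCC[C@H](NC(=O)c3cccc(Cl)c3)C2)cc1` at 674 nM sits within the scatter of it, as the step of a 1.2-fold lower number from compound 1 to compound 2 (0.06 log units; within the scatter) shows. Compound 3 `O=C(N[C@H]1CCC[C@H](NC(=O)c2ccccc2F)C1)c1cccc(Cl)c1` carries 2-fluorophenyl in place of 6-methylpyridin-2-yl on a carbonyl carbon. Among the compounds with values here, the only measured step, a 1.2-fold lower number from compound 1 to compound 2 (0.06 log units; within the scatter), also exchanged the group on that same carbonyl carbon and stayed within the scatter, so no step beyond the scatter is expected here either. Compound 3 is therefore estimated at 600 nM in this assay, between 250 nM and 1500 nM, an expected step of a 1.0-fold higher number from compound 2 to compound 3 (0.01 log units; within the scatter).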

Compound 3, inhibition constant: 760 nM
Beside the measured number, compound 3's estimate is 1.3-fold (0.10 log units) below it; the range from low to high includes it.
By their numbers in this assay, from the lowest: compounds 2, 1 and 3 (each within the scatter of the next).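

In this assay, exchanging 6-methylpyridin-2-yl, with its 1 hydrogen-bond acceptor, for 2-fluorophenyl, with 0, leaves the number within the scatter (a 1.3-fold higher number from compound 2 to compound 3 (0.12 log units; within the scatter)). The exchange of 4-methoxyphenyl for 2-fluorophenyl on the same carbonyl carbon does likewise (a 1.1-fold higher number from compound 1 to compound 3 (0.05 log units; within the scatter)), so all three aromatic groups at this position now give numbers within the scatter of one another. No available evidence accounts for this. Going by these compounds, whether a carboxylic acid, an amine or a cyclohexyl group on this carbonyl carbon would give a step beyond the scatter remains open.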